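The compounds below may be only part of what the source reports. "The series", "measured", "known", "first", "only" and "open" are said of these compounds alone.

Working notes on the series. In an ADME assay on S2 cells (Drosophila melanogaster) for cytotoxicity, read by MTT assay (a lower number here means that less compound is needed, a higher number that more compound is needed for the effect), compound 2 `COc1ccc(NC(=O)/C=C/[C@H]2C[C@@H](O)[C@@H](O)C2)cc1` gives > 180000 nM, which is a limit of the assay rather than a number. Compound 1 `O=C(/C=C/[C@H]1C[C@@H](O)[C@@H](O)C1)Nc1ccccc1` gives > 200000 nM in this assay, again a limit. For the measured compounds named here, the one measured step, a step that the two limits leave unreadable from compound 1 to compound 2, is therefore of unreadable size, since the limit of > 180000 nM in this assay, at which 1 of the 2 values shown sits, and the limit of > 200000 nM in this assay, at which 1 of the 2 values shown sits, are both limits with no measured value behind them.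

Compound 3 `CN(C)c1ccc(NC(=O)/C=C/[C@H]2C[C@@H](O)[C@@H](O)C2)cc1` carries the change (dimethylamino in place of methoxy on an aromatic carbon). Going by the values given here, the only step that bears on it is a step that the two limits leave unreadable from compound 1 to compound 2, and it yields no size; with both neighbours at the limit, no step beyond the scatter in this assay can be read as expected in either direction. Compound 3 is therefore expected to sit at about 200000 nM in this assay, with a range from 90000 nM to 450000 nM. The expected step from compound 2 is a step that the limit leaves unreadable from compound 2 to compound 3, and most likely the assay reports only a limit for compound 3 as well.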

Compound 3, half-maximal effective concentration: > 170000 nM
Compound 3: only a limit was reported (the forecaster's own chance of this, stated with the estimate: 85%); the middle value lies beyond the limit too.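

For the compounds shown here, compound 1, compound 2 and compound 3 all give only limits in this assay, so no step among them can be read. The compounds shown leave open whether any group at this aromatic carbon of the shared core gives a measured value in this assay.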